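Methoxy in Place of Nitro on a Weak Styryl Sulfone

The source may report more compounds than this note shows. Statements on the series, on what has been measured and on what is new or still open speak of the compounds shown alone.

For the measured compounds named here, compound 1 `COc1cc(OC)c(/C=C/S(=O)(=O)Cc2ccc([N+](=O)[O-])cc2)c(OC)c1` is the only member of the set with a number in a functional assay on H157 cells (Homo sapiens) for antiproliferative activity, read by trypan blue exclusion; a higher number here means a weaker inhibitor, a lower number a stronger inhibitor: compound 1 gives 20000 nM. Compound 2 `COc1ccc(CS(=O)(=O)/C=C/c2c(C)cccc2C)cc1` reaches only a limit of the assay in this assay, > 20000 nM. Compound 3 `COc1ccc(CS(=O)(=O)/C=C/c2cc(OC)cc(OC)c2)cc1` likewise stops at a limit, > 20000 nM. Compound 1 therefore stands alone at the weak end of what was measured, and the limit of > 20000 nM in this assay, at which 2 of the 3 values shown sit, is where the other two rest. Compound 4 `COc1ccc(CS(=O)(=O)/C=C/c2c(OC)cc(OC)cc2OC)cc1` differs from compound 1 by methoxy in place of nitro on an aromatic carbon. Going by the values given here, no measured step covers this change, and the two neighbours give no number to build on. The expected step is no change at the digits printed from compound 1 to compound 4 (within the scatter), none beyond the scatter. Compound 4 is estimated at 20000 nM, between 7000 nM and 60000 nM.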

Compound 4, half-maximal inhibitory concentration: 30 nM
Beside the measured number, compound 4's estimate is 670-fold (2.82 log units) above it, outside the stated range (below it).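

In this assay, the change from 4-nitrophenyl to 4-methoxyphenyl gives a 670-fold lower number from compound 1 to compound 4 (2.82 log units; beyond the scatter), so this one place, para to a large group, can carry a large difference in antiproliferative activity. The earlier compounds offered no step to read, and the set now holds a number far from its weak end, where the other values rest: the limit of > 20000 nM in this assay, at which 2 of the 4 values shown sit.

As far as these compounds go, what an amine or a hydroxyl at this place would give remains open. This single pair also cannot tell whether the same change would act alike on a different core.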